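The compounds below may be only part of what the source reports. "The series", "measured", "known", "first", "only" and "open" are said of these compounds alone.

Of the compounds shown here, two have numbers so far in a functional assay on MCF7 cells (Homo sapiens) for antiproliferative activity, read by MTT assay, with a stated time of 72 h; on this read-out lower numbers stand for stronger inhibition and higher numbers for weaker inhibition. Compound 1 (`O=S1(=O)C=Cc2ccc(Nc3ccc(Cl)c(Cl)c3)cc21`) gives 2230 nM, and compound 2 (`O=S1(=O)C=Cc2cccc(Nc3ccc(C(F)(F)F)cc3)c21`) gives 1820 nM. These two values lie within the usual scatter of each other, so compound 2 cannot be separated from compound 1 on this evidence. The two structures differ in more than one place, so no measured single change is available as a guide. Compound 3 (`Cc1ccc(Nc2cccc3c2S(=O)(=O)C=C3)cc1`) carries methyl in place of trifluoromethyl on an aromatic carbon of compound 2, para to a large group: methyl in place of trifluoromethyl on an aromatic carbon. With nothing measured to lean on, only a modest move towards weaker inhibition is expected, and it may stay within the scatter. The estimated step is a 1.6-fold higher number from compound 2 to compound 3 (0.22 log units; within the scatter). Compound 3 is expected at about 3000 nM, with an estimated range of 1000 nM to 9000 nM.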

Compound 3, half-maximal inhibitory concentration: 1890 nM
For compound 3 the middle estimate is 1.6-fold (0.20 log units) above the measured one; measured number inside the range.
By their numbers in this assay, from the lowest: compounds 2, 3 and 1 (each within the scatter of the next).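

In this assay, methyl in place of trifluoromethyl on this aromatic carbon gives a 1.0-fold higher number from compound 2 to compound 3 (0.02 log units; within the scatter), the only single change with a measured size among these compounds. At this place, para to a large group, a group of four heavy atoms and a group of one heavy atom leave compound 2 and compound 3 impossible to tell apart, so this read-out does not separate these two groups. Nothing measured here offers an explanation for this result.

From the compounds shown here alone, it remains open whether the read-out would also fail to separate groups of a different kind at this place, such as an amine, a carboxylic acid or a longer chain. This single pair also cannot show whether the same exchange would give a similar step elsewhere on the shared core.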